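Aryl substituent swap in the series: bromo to methyl

This account rests on a few compounds, and the source may have more. Where it says the series, first, only, none or still open, it means among the compounds named here.

Measured so far:
- compound 1 `COc1ccc(C(/C=C/c2ccc(Cl)cc2)=N/O)cc1` gives 11500 nM in a functional assay (Mus musculus, strain Balb/c) for inhibition, read by ELISA, with a stated time of 72 h; on this read-out lower numbers stand for stronger inhibition and higher numbers for weaker inhibition
- compound 2 `O/N=C(\C=C\c1ccc(Cl)cc1)c1ccc(Br)cc1` gives 14700 nM in this assay

Within the data shown here, compound 2 holds the highest of the two numbers measured so far, but its only neighbour is compound 1, and the step of a 1.3-fold higher number from compound 1 to compound 2 (0.11 log units; within the scatter) lies within the scatter, so the two compounds are not separated on this read-out. Compound 3 `Cc1ccc(C(/C=C/c2ccc(Cl)cc2)=N/O)cc1`, not yet measured, differs from compound 2 in one place: methyl in place of bromo on an aromatic carbon. Among the measured compounds shown here, the single measured step that bears on this position is a 1.3-fold higher number from compound 1 to compound 2 (0.11 log units; within the scatter), in which exchanging one group for another on an aromatic carbon left the number essentially where it was. For the measured compounds named here, no measured compound carries methyl on that carbon, so there is no direct precedent, and the one comparison available suggests the group at this carbon matters little. The step of a 1.1-fold lower number from compound 2 to compound 3 (0.05 log units; within the scatter) is therefore expected to remain within the scatter, with no direction favoured. Compound 3 is estimated at 13000 nM in this assay, with a range from 6500 nM to 28000 nM.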

Compound 3, half-maximal inhibitory concentration: 11600 nM
Beside the measured number, compound 3's estimate is 1.1-fold (0.05 log units) above it, and the stated range covers the measured number.
By their numbers in this assay, from the lowest: compounds 1, 3 and 2 (each within the scatter of the next).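

Methyl in place of bromo on this aromatic carbon, para to a large group, gives a 1.3-fold lower number from compound 2 to compound 3 (0.10 log units; within the scatter) in this assay and adds a third group to the two already read at this place. Methyl in place of methoxy gives a 1.0-fold higher number from compound 1 to compound 3 (0.00 log units; within the scatter) as well, so all three steps among methoxy, bromo and methyl now lie within the scatter, where the earlier compounds offered a single step, and these three groups are not separated on this read-out. No accompanying evidence bears on this result.

Whether an amine, a carboxylic acid or a longer chain on this carbon would move the number beyond the scatter remains open, and the compounds shown give no step of that size at this place. Also open, as far as these compounds go, is whether the chloro group elsewhere in the shared core can be exchanged with as little change in the number as the groups at this carbon.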